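This account rests on a few compounds, and the source may have more. Where it says the series, first, only, none or still open, it means among the compounds named here.

Compound 2 `Cc1ccnc(/C(N)=N/NC(=S)N2CCOCC2)c1` belongs to a small set of three compounds measured in a functional assay on HeLa cells (Homo sapiens) for cytotoxicity, read by MTT assay, with a stated time of 72 h, tested at 1 uM (a lower number here means less inhibition of growth, a higher number more inhibition of growth at the concentration tested), alongside compound 1 `N/C(=N\NC(=S)N1CCOCC1)c1ccccn1` and compound 3 `Cc1cccc(/C(N)=N/NC(=S)N2CCSCC2)n1`. In this assay compound 1 gives 12.7%, while compound 2 gives 39.1% and compound 3 gives 46.5%. Compound 2 thus stands second highest of the three: the step from compound 1 to compound 2, a methyl in place of hydrogen on an aromatic carbon, amounts to a number 26.4 percentage points higher from compound 1 to compound 2 (beyond the scatter), whereas compound 3 sits close enough to compound 2 that the gap lies within the ordinary scatter.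

Compound 4 `Cc1ccnc(/C(N)=N/NC(=S)N2CCCCC2)c1` differs from compound 2 only by piperidin-1-yl in place of morpholin-4-yl on a thiocarbonyl carbon. For the measured compounds named here, no measured step touches that part of the molecule, so no direct guide exists. Going by the values given here, the only hint comes from compound 3, where a different six-membered ring on the thiocarbonyl carbon, together with a different methyl position, gave a number near that of compound 2. A step of a number 2.9 percentage points higher from compound 2 to compound 4 (within the scatter) from compound 2 to compound 4 is therefore expected, in effect none beyond the scatter. Compound 4 is estimated at 42%, within a range from 20% to 65%.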

Compound 4, percent growth inhibition at one concentration: 15.3%
Beside the measured number, compound 4's estimate is 26.7 percentage points above it, outside the stated range (below it).
By their numbers in this assay, from the lowest: compounds 1 and 4 (each within the scatter of the next); then compounds 2 and 3 (each within the scatter of the next).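

In this assay, for the compounds shown here, the group on the thiocarbonyl carbon, which no earlier step had touched, proves to matter: piperidin-1-yl in place of morpholin-4-yl gives a number 23.8 percentage points lower from compound 2 to compound 4 (beyond the scatter). The two rings have the same size, so this single swap of the ring oxygen for a carbon, which also removes the hydrogen-bond acceptor counted on morpholin-4-yl, is enough to shift the read-out beyond the usual scatter. Nothing available here accounts for this drop in growth inhibition.

On these data alone, it remains open how a piperazin-1-yl ring or an open-chain dimethylamino group would behave on this thiocarbonyl carbon. Going by these compounds alone, also open is whether the same swap would give a similar step on the core of compound 1, which lacks the methyl, as this change is seen in only one pair.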